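The source may report more compounds than this note shows. Statements on the series, on what has been measured and on what is new or still open speak of the compounds shown alone.

Of the compounds shown here, three have been tested so far in an ADME assay on Vero cells (Chlorocebus sabaeus) for cytotoxicity, read by CellTiter-Glo, with a stated time of 72 h; a lower number here means that less compound is tolerated, a higher number that more compound is tolerated. Compound 1 (`CC(=O)Nc1cc(/C=C\c2ccc([N+](=O)[O-])o2)ns1`) gives > 50 ug/mL as a limit and not a number. Compound 2 (`CSc1c(C)[n+]([O-])c2ccccc2[n+]1[O-]`) gives > 16 ug/mL which is likewise a limit. For the measured compounds named here, compound 3 (`CCNc1n[n+]([O-])c2ccccc2[n+]1[O-]`) gives 17 ug/mL and this is the only true number of the three, so compound 3 has no firm rank against the other two.

Compound 4 (`CC(C)(C)Nc1n[n+]([O-])c2ccccc2[n+]1[O-]`) has not yet been measured. It differs from compound 3 in one place, with tert-butyl in place of ethyl on a nitrogen on an aromatic ring. Going by the values given here, no two measured compounds differ from each other in just one place, so the data hold no direct example of what a swap of this kind does. Among the compounds with values here, the starting point is therefore compound 3 at 17 ug/mL as the one close measured neighbour. In this assay no step beyond the usual scatter is expected, in either direction. The expected change is a 1.2-fold higher number from compound 3 to compound 4 (0.07 log units; within the scatter) and it stays within that scatter. For compound 4 the estimated value is 20 ug/mL with an expected range from 8 ug/mL to 50 ug/mL as the likely span.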

Compound 4, half-maximal cytotoxic concentration: 8 ug/mL
Beside the measured number, compound 4's estimate is 2.5-fold (0.40 log units) above it; low and high end bracket the measured number.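

For the compounds shown here, putting tert-butyl in place of ethyl on a nitrogen on an aromatic ring gives the first direct reading of this position in this assay, with a 2.1-fold lower number from compound 3 to compound 4 (0.33 log units; beyond the scatter) as the result. The group on this nitrogen therefore matters to how much compound the cells tolerate: on the shared core, the change moves the number by more than repeat measurements normally would, and tert-butyl is the less tolerated of the two groups. The step is modest and rests on this single pair, and nothing in the data shown explains why it runs in this direction.

From the compounds shown here alone, it remains open whether a branched group of intermediate size, such as isopropyl, would fall between these two compounds, or whether a longer unbranched chain, such as n-butyl, would give a similar drop, which would help separate the effect of branching from that of simply adding carbon. Going by these compounds, it is also open what this nitrogen would tolerate with a chain ending in an amine or a carboxylic acid, since the ethyl and tert-butyl groups compared here are both plain hydrocarbon groups.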